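A few compounds are considered here, and "the series" means these few. Any claim that something is new, unique, unknown or untested is made for them only; others in the source may bear on it.

Measured so far in an assay on Prostate gland for inhibition of steroid 5-alpha-reductase (Rattus norvegicus); on this read-out lower numbers stand for stronger inhibition and higher numbers for weaker inhibition:
compound 1 `C/C(=C\C(=O)Nc1ccccc1OCCCC(=O)O)c1ccc2c(ccn2Cc2ccc(C(F)(F)F)cc2)c1` – 300 nM
compound 2 `C/C(=C\C(=O)Nc1ccccc1OCCCC(=O)O)c1ccc2c(ccn2Cc2ccc(C(C)(C)C)cc2)c1` – 170 nM

Compound 2 shows the lowest of the two numbers in this assay, with compound 1 as its nearest neighbour; the step of a 1.8-fold lower number from compound 1 to compound 2 (0.25 log units; within the scatter) lies within the scatter, so the two cannot be ordered. Compound 3 `C/C(=C\C(=O)Nc1ccccc1OCCCC(=O)O)c1ccc2c(ccn2C(C)c2ccccc2)c1` is not yet measured. It differs from compound 2 by 1-phenylethyl in place of 4-(tert-butyl)benzyl on an aromatic nitrogen. Going by the values given here, the only measured step, from compound 1 to compound 2, exchanges a group on that benzyl ring and was small, within the scatter. Among the compounds with values here, no measured step removes the 4-(tert-butyl) group or shortens the link to the phenyl ring, so the present change is further from the data than that step. For compound 3 a modest weakening is expected, a 2.4-fold higher number from compound 2 to compound 3 (0.37 log units; beyond the scatter), amounting to an estimated 400 nM in this assay, with a range from 120 nM to 1300 nM.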

Compound 3, half-maximal inhibitory concentration: 19 nM
For compound 3 the middle estimate is 21-fold (1.32 log units) above the measured one, outside the stated range (below it).
By their numbers in this assay, from the lowest: compound 3; then compounds 2 and 1 (each within the scatter of the next).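

In this assay, the group on the aromatic nitrogen turns out to matter far more than the two earlier compounds suggested: their exchange on the benzyl ring stayed within the scatter, whereas 1-phenylethyl gives an 8.9-fold lower number from compound 2 to compound 3 (0.95 log units; beyond the scatter) and a 16-fold lower number from compound 1 to compound 3 (1.20 log units; beyond the scatter). Both steps lie beyond the scatter, so this position can shift the number substantially while the rest of the structure stays the same. The shown data contain no independent evidence that would explain this shift.

1-Phenylethyl differs from each substituted benzyl group both at the ring substituent and at the carbon linking the ring to the nitrogen. The compounds shown leave these two changes unseparated. A plain benzyl group on the same nitrogen would show how the number responds with only the ring substituent removed.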